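The source may hold more compounds than are shown below. What is called first, only, known or untested is meant among the compounds shown, and "the series" means these compounds.

Of the compounds shown here, three have been measured in an assay on isolated protein for antagonist activity at Bile acid receptor (Homo sapiens), read by HTRF, with a stated time of 30 min; on this read-out higher numbers stand for weaker inhibition and lower numbers for stronger inhibition. Compound 1 `COc1ccccc1C(=O)Oc1ccc(O)c(C(C)(C)C)c1` reaches only the limit of this assay, > 100000 nM. That limit is the one described in the limit of > 100000 nM in this assay, at which 1 of the 3 values shown sits. Compound 2 `CC(C)(C)c1cc(OC(=O)c2c(Cl)cc([N+](=O)[O-])cc2Cl)ccc1O` gives 5900 nM in this assay. Compound 3 `CC(C)(C)c1cc(NC(=O)c2c(Cl)cc(N)cc2Cl)ccc1O` gives 5200 nM in this assay; of the two numbers shown it is the one at the low end, but its gap to compound 2 lies within the scatter, so the two compounds show the same thing. Going by the values given here, no two measured compounds differ in a single place, so no measured step is at hand to guide the next one.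

Compound 4 `CC(C)(C)c1cc(NC(=O)c2c(Cl)cc(NC3CCCCC3)cc2Cl)ccc1O` differs from compound 3 in one place: cyclohexyl in place of hydrogen on a nitrogen on an aromatic ring. Among the compounds with values here, with no measured step to lean on, the expectation rests on the structural change alone, and the expected step is a 2.6-fold lower number from compound 3 to compound 4 (0.41 log units; beyond the scatter), toward lower numbers and only a little beyond the scatter. Compound 4 is therefore estimated at 2000 nM in this assay, with a range from 500 nM to 8000 nM.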

Compound 4, half-maximal inhibitory concentration: 2500 nM
Beside the measured number, compound 4's estimate is 1.3-fold (0.10 log units) below it; the range from low to high includes it.
By their numbers in this assay, from the lowest: compound 4; then compounds 3 and 2 (each within the scatter of the next). At a limit, above all of these: compound 1.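

The first single change measured in this set shows that the nitrogen on an aromatic ring can carry cyclohexyl in place of hydrogen, and that in this assay this change gives a 2.1-fold lower number from compound 3 to compound 4 (0.32 log units; beyond the scatter). The step is modest, so this position responds to a large added ring but does not yet show a steep dependence on what sits there. Nothing known here accounts for the size or direction of this step.

Going by these compounds, whether the ring itself matters stays open, since a smaller ring such as cyclopentyl, an open chain such as n-hexyl, or an aromatic phenyl on the same nitrogen could each give a different number. Also open, on these data alone, is how a hydroxyl or a carboxylic acid on the cyclohexyl ring would change the number.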